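Adding fluoro to the core of compound 3

The compounds below may be only part of what the source reports. "The series", "measured", "known", "first", "only" and "open" are said of these compounds alone.

In a functional assay on HeLa cells (Homo sapiens) for cytotoxicity, read by MTT assay, with a stated time of 48 h (on this read-out higher numbers stand for weaker inhibition and lower numbers for stronger inhibition), compound 1 `O=C(O)CN1C(=O)/C(=C/c2nc3ccccc3n2Cc2ccc(Br)cc2F)SC1=S` gives > 50000 nM as a limit of the assay and not a number. Compound 2 `N#Cc1ccc(Cn2c(/C=C3\SC(=S)N(CC(=O)O)C3=O)nc3ccccc32)cc1` reads 16300 nM in this assay and compound 3 `Cc1ccc(Cn2c(/C=C3\SC(=S)N(CC(=O)O)C3=O)nc3ccccc32)cc1` reads 1280 nM there, which is the lower of the two actual numbers. The gap between them is a 13-fold lower number from compound 2 to compound 3 (1.10 log units; beyond the scatter) for methyl in place of cyano on an aromatic carbon. Measured against the limit, the other steps are an at least 39-fold lower number from compound 1 to compound 3 (1.59 log units; beyond the scatter) and an at least 3.0-fold lower number from compound 1 to compound 2 (0.48 log units; beyond the scatter) at that same site.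

Compound 4 `Cc1ccc(Cn2c(/C=C3\SC(=S)N(CC(=O)O)C3=O)nc3ccc(F)cc32)cc1` differs from compound 3 by fluoro in place of hydrogen on an aromatic carbon in one place: fluoro in place of hydrogen on an aromatic carbon, in a six-membered aromatic ring of carbon only that is part of a fused system. Within the data shown here, all the measured steps concern the group on the saturated chain carbon bound to an aromatic nitrogen, so none of them tests this ring directly. Among the measured compounds shown here, they show only that a single swap at that other site can move the number a long way. A small step is therefore expected in this assay and it may lean slightly towards a higher number, though the direction remains uncertain. The estimated change is a 1.6-fold higher number from compound 3 to compound 4 (0.19 log units; within the scatter) for this swap. Compound 4 is expected at 2000 nM with a range from 600 nM to 8000 nM in this estimate.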

Compound 4, half-maximal inhibitory concentration: 3920 nM
Estimate against measurement, compound 4: 2.0-fold (0.29 log units) below; the range from low to high includes it.
By their numbers in this assay, from the lowest: compound 3; then compound 4; then compound 2. At a limit, above all of these: compound 1.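

Fluoro in place of hydrogen on this aromatic carbon, meta to a fused ring and para to a fused ring, gives in this assay a 3.1-fold higher number from compound 3 to compound 4 (0.49 log units; beyond the scatter), a modest step towards weaker inhibition. Among these compounds, every earlier step concerned the group on the saturated chain carbon, so this is the first sign that the six-membered aromatic ring of the core also affects the read-out, and that the entry of one heavy atom there is enough to do so. The information available gives no measured property that bears on this step and offers no explanation for it.

The compounds shown leave open whether chloro, methoxy or an amine on this same aromatic carbon would shift the number in the same direction, and whether fluoro on the other carbons of this ring would give a similar step. They also leave open whether the step would hold with the cyano group of compound 2 in place of the methyl group of compound 3 at the other site.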